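Hydrogen in place of the acyl group on the ring nitrogen

A few compounds are considered here, and "the series" means these few. Any claim that something is new, unique, unknown or untested is made for them only; others in the source may bear on it.

Measured so far:
compound 1 `O=C(Nc1cc(C(F)(F)F)cc(C(F)(F)F)c1)C1CCc2ccccc2N1C(=O)c1cccc(Cl)c1` — 1190 nM
compound 2 `O=C(Nc1ccccc1C(F)(F)F)C1CCc2ccccc2N1C(=O)c1ccccc1Cl` — 2530 nM

In a functional assay on MDA-MB-231 cells (Homo sapiens) for cytotoxicity, read by sulforhodamine B assay, with a stated time of 72 h (on this read-out lower numbers stand for stronger inhibition of growth and higher numbers for weaker inhibition of growth), compound 1 gives 1190 nM, the lower of the two numbers; compound 2 gives 2530 nM, a gap beyond the usual scatter. Compound 3 `O=C(Nc1cc(C(F)(F)F)cc(C(F)(F)F)c1)C1CCc2ccccc2N1` is not yet measured. It differs from compound 1 in one place: hydrogen in place of (3-chlorophenyl)carbonyl on a nitrogen on an aromatic ring in a ring. For the measured compounds named here, no step between measured compounds informs this change, so the expectation rests on the two values alone. A large step toward weaker inhibition of growth, well beyond the scatter, is expected a 10-fold higher number from compound 1 to compound 3 (1.00 log units; beyond the scatter). For compound 3 the estimate is 12000 nM, within 2500 nM to 60000 nM.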

Compound 3, concentration for 50% growth inhibition: 8270 nM
For compound 3 the middle estimate is 1.5-fold (0.16 log units) above the measured one; the range from low to high includes it.
By their numbers in this assay, from the lowest: compound 1; then compound 2; then compound 3.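

In this assay the loss of the (3-chlorophenyl)carbonyl from this ring nitrogen gives a 6.9-fold higher number from compound 1 to compound 3 (0.84 log units; beyond the scatter), so in this pair the acyl group contributes to growth inhibition. With hydrogen at this position, compound 3 still gives 8270 nM, so the rest of the structure retains measurable inhibition. No measurement at hand bears on the reason for this step.

Still open, on these data alone, is whether the carbonyl or the chlorophenyl ring accounts for the step. An acetyl group or a benzyl group on this nitrogen would separate the two.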